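Acyl aryl swap on compound 1: from dichlorophenyl to trifluoromethylphenyl

The source may hold more compounds than are shown below. What is called first, only, known or untested is meant among the compounds shown, and "the series" means these compounds.

Measured so far:
compound 1 `COc1cc(Cl)cc(-c2nn(-c3cccc(NC(=O)c4ccc(Cl)c(Cl)c4)c3)cc2-c2ccncc2)c1` — 79.2%
compound 2 `COc1cc(Cl)cc(-c2nn(-c3cccc(NC(=O)Nc4ccc(Cl)c(Cl)c4)c3)cc2-c2ccncc2)c1` — 37.8%
compound 3 `COc1cc(Cl)cc(-c2nn(-c3cccc(NC(=O)Nc4cccc(C(F)(F)F)c4)c3)cc2-c2ccncc2)c1` — 34.1%

In a functional assay on OVCAR-5 cells (Homo sapiens) for inhibition, read by sulforhodamine B assay, with a stated time of 48 h, tested at 10 uM (on this read-out lower numbers stand for a stronger effect and higher numbers for a weaker effect at the one concentration tested), compound 1 gives 79.2%, the highest of the three numbers; compound 2 lies a number 41.4 percentage points lower from compound 1 to compound 2 (beyond the scatter) and compound 3 lies a number 45.1 percentage points lower from compound 1 to compound 3 (beyond the scatter), both well beyond the scatter. Both of those steps, however, replace the aryl group on the carbonyl carbon with an arylamino group, so they change the linker rather than the aryl group alone. Among the measured compounds shown here, the one step that keeps the linker and only exchanges 3,4-dichlorophenyl for 3-(trifluoromethyl)phenyl is a number 3.7 percentage points lower from compound 2 to compound 3 (within the scatter), which is within the scatter.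

Compound 4 `COc1cc(Cl)cc(-c2nn(-c3cccc(NC(=O)c4cccc(C(F)(F)F)c4)c3)cc2-c2ccncc2)c1` is the next step from compound 1: 3-(trifluoromethyl)phenyl in place of 3,4-dichlorophenyl on a carbonyl carbon. The same aryl exchange on the amide-type nitrogen, seen from compound 2 to compound 3, moved the read-out only within the scatter, so for compound 4 no step beyond the scatter is expected, with a number 1.2 percentage points lower from compound 1 to compound 4 (within the scatter). The estimate for compound 4 is therefore 78%, expected to fall between 62% and 94%.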

Compound 4, a percentage reported as activity, at one concentration (the size of the read-out at that concentration, not a potency): 84.1%
Beside the measured number, compound 4's estimate is 6.1 percentage points below it; measured number inside the range.
By their numbers in this assay, from the lowest: compounds 3 and 2 (each within the scatter of the next); then compounds 1 and 4 (each within the scatter of the next).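

In this assay, a number 4.9 percentage points higher from compound 1 to compound 4 (within the scatter) shows that, with a carbonyl carbon bearing the aryl group directly, exchanging 3,4-dichlorophenyl for 3-(trifluoromethyl)phenyl leaves the read-out unresolved, matching the arylamino pair. With the aryl group held as 3-(trifluoromethyl)phenyl, a number 50 percentage points higher from compound 3 to compound 4 (beyond the scatter) now gives a second matched comparison of the linker, and a number 46.3 percentage points higher from compound 2 to compound 4 (beyond the scatter) runs the same way, so across these four compounds the arylamino group, not the choice between these two aryl groups, separates the numbers. Nothing available here explains this difference.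

Open, on these data alone, is whether the lower numbers depend on an aryl group on the nitrogen, as a benzylamino group or a short alkylamino chain on the carbonyl carbon would test. Also open, as far as these compounds go, is how a carboxylic acid or an amine on the aryl ring would affect the arylamino compounds.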